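Oxolan-2-yl in place of methyl on compound 1

This account rests on a few compounds, and the source may have more. Where it says the series, first, only, none or still open, it means among the compounds named here.

Values so far in a physicochemical assay for solubility, measured as kinetic solubility; on this read-out lower numbers stand for lower solubility and higher numbers for higher solubility
- compound 1 `Cc1cc(C)c(CN2CCc3c(Cl)cc([C@H](C)CO)c(Cl)c3C2=O)c(=O)[nH]1` gives 131000 nM
- compound 2 `CCOC(c1cc(Cl)c2c(c1Cl)C(=O)N(Cc1c(C)cc(C)[nH]c1=O)CC2)C1CS(=O)(=O)C1` gives 453000 nM; 446000 nM (2 entries)

Compound 1 carries one number in this assay and one further entry without a single number, and its number sits under the two entries of compound 2 (the several entries of compound 2 in this assay, 453000 nM; 446000 nM (2 entries)).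

Compound 3 `Cc1cc(C)c(CN2CCc3c(Cl)cc([C@@H](CO)[C@@H]4CCCO4)c(Cl)c3C2=O)c(=O)[nH]1` follows from compound 1 with oxolan-2-yl in place of methyl on a saturated chain carbon bound to an aromatic carbon and a saturated chain carbon.

Going by the values given here, no step confined to one place has been measured in this assay so far, so the expectation rests on thin ground. Compound 2 (453000 nM; 446000 nM (2 entries)) differs from compound 1 in more than one place and offers only a loose hint upward. A small rise is expected, possibly not beyond the usual scatter. The estimated move a 1.5-fold higher number from compound 1 to compound 3 (0.18 log units; within the scatter) stays modest. For compound 3 the expected value is 200000 nM with an estimated range from 80000 nM to 480000 nM as the working bracket.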

Compound 3, solubility: 550000 nM
For compound 3 the middle estimate is 2.8-fold (0.44 log units) below the measured one; measured number above the stated range.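

Going by these compounds alone, this is the first step confined to one place in this assay: on a saturated chain carbon bound to an aromatic carbon and a saturated chain carbon, oxolan-2-yl in place of methyl gives a 4.2-fold higher number from compound 1 to compound 3 (0.62 log units; beyond the scatter). The step lies beyond the scatter, so this position is not silent in this read-out, and the larger group carrying one five-membered non-aromatic ring comes with a higher number rather than a lower one. The only other high readings belong to a compound that differs from compound 1 in more than one place, so on their own they tie the rise to no single group, whereas this step does: the several entries of compound 2 in this assay, 453000 nM; 446000 nM (2 entries)

A single step cannot separate the contributions of the new ring, its oxygen and the added stereocentre, so the cause of the rise remains unassigned. As far as these compounds go, whether a cyclopentyl ring, a longer open chain or an amine on the same carbon would move this assay in the same direction remains open, as does the effect of the opposite configuration at the oxolan-2-yl stereocentre.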